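From compound 3 to a chloro analogue

This account rests on a few compounds, and the source may have more. Where it says the series, first, only, none or still open, it means among the compounds named here.

Three compounds measured in a physicochemical assay for solubility, read by HPLC, in phosphate buffer, measured as kinetic solubility, at pH 7.4 (on this read-out higher numbers stand for higher solubility and lower numbers for lower solubility), so far
- compound 1 (`CCC(=O)c1cc(-c2ccc(Cl)cc2)[nH]c1C`) gives 900 nM
- compound 2 (`CCOC(=O)c1cc(-c2ccc(Cl)cc2)n(-c2ccc3cc[nH]c3c2)c1C`) gives 5100 nM
- compound 3 (`CCC(=O)c1cc(-c2ccccc2)n(-c2ccc(S(N)(=O)=O)cc2)c1C`) gives 14100 nM

Compound 3 stands highest of the three, with compound 2 nearest and compound 1 furthest, both gaps beyond the usual scatter. Compound 4 (`CCC(=O)c1cc(-c2cccc(Cl)c2)n(-c2ccc(S(N)(=O)=O)cc2)c1C`) differs from compound 3 by chloro in place of hydrogen on an aromatic carbon, which turns phenyl to 3-chlorophenyl. For the measured compounds named here, no measured pair isolates this change. Compound 1 (900 nM) and compound 2 (5100 nM) also carry a chlorophenyl group and read lower, but they differ from compound 3 elsewhere too, so this is weak guidance. A moderate fall in this assay is expected, estimated as a 2.6-fold lower number from compound 3 to compound 4 (0.41 log units; beyond the scatter) and probably just beyond the scatter. Compound 4 is estimated at 5500 nM (expected range 2000 nM to 12000 nM).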

Compound 4, solubility: 12600 nM
Compound 4: the middle estimate sits 2.3-fold (0.36 log units) below what was measured, outside the stated range (above it).
By their numbers in this assay, from the lowest: compound 1; then compound 2; then compounds 4 and 3 (each within the scatter of the next).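

In this assay, the change from phenyl to 3-chlorophenyl amounts to a 1.1-fold lower number from compound 3 to compound 4 (0.05 log units; within the scatter). This single matched pair shows that, on the core shared by these two compounds, chloro in place of hydrogen at this place, meta to a large group, gives no change that can be told from scatter. Nothing available explains this result. From the compounds shown here alone, whether a methoxy group or an amine at the same place would also leave the read-out unchanged remains open. So does whether chloro on another carbon of this ring would do so.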